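Swapping methyl for trifluoromethyl on compound 2

The source may report more compounds than this note shows. Statements on the series, on what has been measured and on what is new or still open speak of the compounds shown alone.

Compound 1 `Fc1ccccc1Cc1nc(-c2nc(C(F)F)n[nH]2)n2ccccc12`: 62 mL.min-1.g-1
Compound 2 `Cc1n[nH]c(-c2nc(Cc3ccccc3F)c3ccccn23)n1`: 124 mL.min-1.g-1

Both numbers come from an in vitro ADME assay on microsomes from liver (Homo sapiens) for metabolic stability; a lower number here means slower removal, a higher number faster removal of the compound. Among the measured compounds shown here, with only two numbers, compound 2 cannot be set apart from its one neighbour: the single measured step reads a 2.0-fold higher number from compound 1 to compound 2 (0.30 log units; within the scatter). That step puts methyl in place of difluoromethyl on an aromatic carbon.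

Compound 3 `Fc1ccccc1Cc1nc(-c2nc(C(F)(F)F)n[nH]2)n2ccccc12` is reached from compound 2 by trifluoromethyl in place of methyl on an aromatic carbon. In words, this is trifluoromethyl in place of methyl on an aromatic carbon of a five-membered aromatic ring with 3 nitrogen. For the measured compounds named here, the only guide is the step of a 2.0-fold higher number from compound 1 to compound 2 (0.30 log units; within the scatter), which changes the group on that same carbon and stays small. A large move is therefore not expected, and the lean toward a lower number is only tentative. The expected step is a 1.8-fold lower number from compound 2 to compound 3 (0.25 log units; within the scatter). For compound 3 the estimated value is 70 mL.min-1.g-1, with an expected range of 33 mL.min-1.g-1 to 140 mL.min-1.g-1.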

Compound 3, intrinsic clearance in microsomes: 72 mL.min-1.g-1
Compound 3: the middle estimate sits 1.0-fold (0.01 log units) below what was measured, within the range that was stated.
By their numbers in this assay, from the lowest: compounds 1, 3 and 2 (each within the scatter of the next).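

In this assay this carbon of the five-membered aromatic ring with 3 nitrogen has now carried three groups, and trifluoromethyl reads as a 1.7-fold lower number from compound 2 to compound 3 (0.24 log units; within the scatter) against methyl, so these two cannot be told apart. Against difluoromethyl the reading is a 1.2-fold higher number from compound 1 to compound 3 (0.06 log units; within the scatter) and shows that fluoro in place of the last hydrogen of that group also leaves the compounds indistinguishable, a comparison between two fluorinated groups that the earlier pair did not offer. No measurement shown bears on why these numbers stand where they do.

From the compounds shown here alone, whether a different kind of group on this carbon, such as an amine, a carboxylic acid or a longer chain, would give a step beyond the scatter remains open. Also open, going by these compounds, is whether the same three groups would read alike on a different core.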